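This account rests on a few compounds, and the source may have more. Where it says the series, first, only, none or still open, it means among the compounds named here.

Measured in an in vitro ADME assay on microsomes from liver (Mus musculus) for pharmacokinetics, read by LC-MS; a higher number here means faster removal of the compound, a lower number slower removal:
- Compound 1 `Cc1ccc2c(c1)nc(C)n2-c1ccc(C(=O)NC2CC2)s1`: > 72 mL/min/kg (a limit, not a number)
- Compound 2 `Cc1nc2ccc(OC(F)(F)F)cc2n1-c1ccc(C(=O)NC2CC2)s1`: 41 mL/min/kg

The reading of compound 1 is the limit of > 72 mL/min/kg in this assay, at which 1 of the 2 values shown sits. Compound 3 `Cc1nc2cc(C(F)(F)F)ccc2n1-c1ccc(C(=O)NC2CC2)s1` has trifluoromethyl in place of methyl on an aromatic carbon. For the measured compounds named here, no measured pair shows this change alone. The nearest guide is compound 2, which also carries a fluorine-bearing group and gives 41 mL/min/kg. On that basis, slower removal is expected, with an estimated step of an at least 1.6-fold lower number from compound 1 to compound 3 (0.20 log units; that floor lies within the scatter). For compound 3 the expected clearance is 45 mL/min/kg, with an estimated range of 24 mL/min/kg to 72 mL/min/kg.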

Compound 3, clearance: > 72 mL/min/kg
Compound 3 ended at the assay's limit; the forecaster's own chance of this, stated with the estimate: 15%; middle value at least 1.6-fold (0.20 log units) from the limit.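

No step can be read from compound 1 to compound 3, since both readings are limits and not numbers: the limit of > 72 mL/min/kg in this assay, at which 2 of the 3 values shown sit.

The compounds shown leave open whether trifluoromethyl in place of methyl on an aromatic carbon changes clearance at all, and by how much.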